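Shortening a side chain on compound 2

The source may hold more compounds than are shown below. What is called first, only, known or untested is meant among the compounds shown, and "the series" means these compounds.

Measured in an assay on isolated protein for inhibition of Rho-associated protein kinase 1 (Homo sapiens), read by scintillation counting, radiometric assay and 33P incorporation, with a stated time of 40 min, in the presence of a further agent that is not named here; on this read-out higher numbers stand for weaker inhibition and lower numbers for stronger inhibition:
compound 1 `COc1ccc(C(=O)Nc2cccc(NC(=O)COc3ccc4c(=O)ccoc4c3)c2)cc1`: 18 nM
compound 2 `CC(C)(C)c1cc(C(=O)Nc2cccc(NC(=O)COc3ccc4c(=O)ccoc4c3)c2)no1`: 101 nM

Among the measured compounds shown here, compound 2 holds the higher of the two numbers; the single measured step, a 5.6-fold higher number from compound 1 to compound 2 (0.75 log units; beyond the scatter), put 5-(tert-butyl)-1,2-oxazol-3-yl in place of 4-methoxyphenyl on the carbonyl carbon. Compound 3 `Cc1cc(C(=O)Nc2cccc(NC(=O)COc3ccc4c(=O)ccoc4c3)c2)no1` differs from compound 2 by methyl in place of tert-butyl on an aromatic carbon. No measured step alters this group: the only step shown swaps a whole ring, so it says little about shortening a chain at the same position. A step expected to stay within the scatter, a 1.5-fold higher number from compound 2 to compound 3 (0.17 log units; within the scatter), is the working assumption. Compound 3 is estimated at 150 nM, between 50 nM and 450 nM.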

Compound 3, half-maximal inhibitory concentration: 68 nM
Compound 3: middle estimate off by 2.2-fold (0.34 log units), on the high side, and the stated range covers the measured number.
By their numbers in this assay, from the lowest: compound 1; then compounds 3 and 2 (each within the scatter of the next).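

On the five-membered aromatic ring, methyl can stand in place of tert-butyl with a step that stays within the scatter (a 1.5-fold lower number from compound 2 to compound 3 (0.17 log units; within the scatter)), so these two groups cannot be told apart at this position. Even with the smaller group, the gap to the 4-methoxyphenyl compound remains beyond the scatter (a 3.8-fold higher number from compound 1 to compound 3 (0.58 log units; beyond the scatter)). Nothing available explains either step. Still open, from the compounds shown here alone, is whether a bare hydrogen, a cyclopropyl group or an amine on this ring carbon would also stay within the scatter of compound 3.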